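Amide nitrogen substituent and agonist potency, compound 1 to 4

A few compounds are considered here, and "the series" means these few. Any claim that something is new, unique, unknown or untested is made for them only; others in the source may bear on it.

For the measured compounds named here, compound 1 `Cc1ccc(OCC(=O)N(Cc2cccs2)C2COC2)cc1` is the least potent of the three measured members: in an assay on HEK293 cells for agonist activity at transient receptor potential cation channel subfamily M member 8 (Homo sapiens), read by fluorescence and calcium flux, with a stated time of 15 min (a lower number here means that less compound is needed, a higher number that more compound is needed for the effect), compound 1 gives 23000 nM, beyond the scatter from both others. Compound 2 `CCN(Cc1cccs1)C(=O)COc1ccc(OC)cc1` gives 120 nM and compound 3 `CCN(Cc1ccsc1)C(=O)COc1ccc(C)cc1` gives 88 nM; neither carries oxetan-3-yl on the amide-type nitrogen. Compound 4 `Cc1ccc(OCC(=O)N(Cc2cccs2)c2cccnc2)cc1` differs from compound 1 in one place (pyridin-3-yl in place of oxetan-3-yl on an amide-type nitrogen). Going by the values given here, no measured pair isolates this change, so the expectation rests only on compound 1 standing far above compound 2 and compound 3 with a different group at that position. A downward step in this assay is expected, a 9.2-fold lower number from compound 1 to compound 4 (0.96 log units; beyond the scatter), larger than the scatter but uncertain in size. Compound 4 is estimated to give 2500 nM, in the range 300 nM to 15000 nM.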

Compound 4, half-maximal effective concentration: 198 nM
For compound 4 the middle estimate is 13-fold (1.10 log units) above the measured one; measured number outside the range, below it.
By their numbers in this assay, from the lowest: compounds 3, 2 and 4 (each within the scatter of the next, the first and the last beyond it); then compound 1.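

In this assay, for the compounds shown here, the first single-change pair shows that the substituent on the amide-type nitrogen alone can move the number substantially: pyridin-3-yl in place of oxetan-3-yl gives a 120-fold lower number from compound 1 to compound 4 (2.07 log units; beyond the scatter). The high number of compound 1 therefore depends on oxetan-3-yl at this position, with the rest of the structure unchanged. Nothing available explains the size of this step.

From the compounds shown here alone, whether the step follows from the ring nitrogen of pyridin-3-yl, the aromatic ring or the ring size remains open. Phenyl or cyclobutyl on the same nitrogen would help separate these.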